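A few compounds are considered here, and "the series" means these few. Any claim that something is new, unique, unknown or untested is made for them only; others in the source may bear on it.

Among the compounds with values here, only two compounds built on one shared core have numbers so far in a functional assay on HepG2 cells (Homo sapiens) for inhibition, read by sulforhodamine B assay, with a stated time of 74 h; a higher number here means a weaker inhibitor, a lower number a stronger inhibitor. Compound 1 `Cc1ccccc1S(=O)(=O)N1C(=O)COC12C=CC(=O)C=C2`, with 2-methylphenyl on the sulfonyl sulfur, gives 750 nM. Compound 2 `O=C1C=CC2(C=C1)OCC(=O)N2S(=O)(=O)c1ccc(Cl)cc1`, with 4-chlorophenyl in that place, gives 860 nM. Within the data shown here, compound 2 therefore stands level with the only other measured compound, and neither can be ranked above the other.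

The next compound, compound 3 `O=C1C=CC2(C=C1)OCC(=O)N2S(=O)(=O)c1ccc(C(F)(F)F)cc1`, keeps everything in compound 2 except one group: trifluoromethyl in place of chloro on an aromatic carbon. The new group is trifluoromethyl in place of chloro on an aromatic carbon. Among the measured compounds shown here, no measured pair makes this exact exchange, so the evidence is indirect. For the measured compounds named here, the one measured step that touches this part of the molecule is a 1.1-fold higher number from compound 1 to compound 2 (0.06 log units; within the scatter), and it replaced a different group. Since that step is so small, no change beyond the scatter is expected in this assay, and neither direction is favoured. The estimated step is a 1.1-fold lower number from compound 2 to compound 3 (0.04 log units; within the scatter). For compound 3 the expected value is 780 nM, with an estimated range from 350 nM to 1700 nM.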

Compound 3, half-maximal inhibitory concentration: 750 nM
Estimate against measurement, compound 3: 1.0-fold (0.02 log units) above; measured number inside the range.
By their numbers in this assay, from the lowest: compounds 1, 3 and 2 (each within the scatter of the next).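

In this assay, the exchange on an aromatic carbon para to a large group gives a 1.1-fold lower number from compound 2 to compound 3 (0.06 log units; within the scatter) and so leaves the number within the scatter, even though trifluoromethyl brings 4 heavy atoms where chloro has 1 heavy atom. Within the data shown here, the earlier step changed the whole group on the sulfonyl sulfur, from 2-methylphenyl to 4-chlorophenyl, whereas this one keeps the ring and the place fixed and exchanges only the group standing there, so it is the first reading of a single place on that ring. No measurement shown here offers an explanation for why these two groups give numbers so close together.

Chloro and trifluoromethyl both have 0 hydrogen-bond donors, 0 hydrogen-bond acceptors and no net charge, so the compounds shown leave open how a group of a different kind at this same place, such as an amine, a carboxylic acid or a longer chain, would read in this assay and whether the number would then move beyond the scatter. They also leave open whether any change to the shared core itself, rather than to the aromatic ring on the sulfonyl sulfur, would shift the number.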